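Swapping 4-chlorophenyl for cyclohexyl on a carbonyl carbon

The source may hold more compounds than are shown below. What is called first, only, known or untested is meant among the compounds shown, and "the series" means these compounds.

In a functional assay on OCI-Ly3 cells (Homo sapiens) for inhibition, read by CellTiter-Glo, with stated times of 48 h and 96 h (on this read-out lower numbers stand for stronger inhibition of growth and higher numbers for weaker inhibition of growth), so far:
compound 1 `CC(C)[C@H](NC(=O)c1cccc(Br)c1)C(=O)N1CCC[C@H]1C(=O)N[C@@H](CCCNC(=N)N)C(=O)CF` gives 530 nM
compound 2 `CC(C)[C@H](NC(=O)c1ccc(Cl)cc1)C(=O)N1CCC[C@H]1C(=O)N[C@@H](CCCNC(=N)N)C(=O)CF` gives 1240 nM

Compound 2 holds the higher of the two numbers, so it inhibits growth less strongly than compound 1. Compound 3 `CC(C)[C@H](NC(=O)C1CCCCC1)C(=O)N1CCC[C@H]1C(=O)N[C@@H](CCCNC(=N)N)C(=O)CF` carries cyclohexyl in place of 4-chlorophenyl on a carbonyl carbon. For the measured compounds named here, the only measured guide is a 2.3-fold higher number from compound 1 to compound 2 (0.37 log units; beyond the scatter) at that same carbonyl carbon. Going by the values given here, no measured compound has a non-aromatic ring there, so a step of similar size in this assay is expected at most, leaning towards a higher number. The estimate means a 1.3-fold higher number from compound 2 to compound 3 (0.11 log units; within the scatter) as the expected step. For compound 3 the estimated value is 1600 nM with an expected range from 550 nM to 4500 nM in this read-out.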

Compound 3, concentration for 50% growth inhibition: 940 nM
Compound 3: middle estimate off by 1.7-fold (0.23 log units), on the high side; the measured number falls inside the stated range.
By their numbers in this assay, from the lowest: compounds 1, 3 and 2 (each within the scatter of the next, the first and the last beyond it).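

In this assay, the aromatic ring on this carbonyl carbon can give way to a non-aromatic ring without a step beyond the scatter: the swap from 4-chlorophenyl to cyclohexyl gives a 1.3-fold lower number from compound 2 to compound 3 (0.12 log units; within the scatter), and the swap from 3-bromophenyl to cyclohexyl gives a 1.8-fold higher number from compound 1 to compound 3 (0.25 log units; within the scatter). Among these three compounds, then, an aromatic ring is not required at this position for growth inhibition in this range. Nothing available explains this result. Still open, going by these compounds, is how an amine, a carboxylic acid or an open hexyl chain would read on this carbonyl carbon.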